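Aryl swap on the shared core and cell cytotoxicity

The compounds below may be only part of what the source reports. "The series", "measured", "known", "first", "only" and "open" are said of these compounds alone.

Compound 1 `COc1ccc(-c2cc(C)c(Nc3ccnc(Nc4ccc(C#N)cc4)n3)c(C)c2)cc1`, compound 2 `Cc1cc(-c2ccccc2)cc(C)c1Nc1ccnc(Nc2ccc(C#N)cc2)n1` and compound 3 `Cc1cc(-c2cccc(F)c2)cc(C)c1Nc1ccnc(Nc2ccc(C#N)cc2)n1` share one core and differ only in the aryl group carried on it. In an ADME assay on MT4 cells (Homo sapiens) for cytotoxicity, read by MTT assay, with a stated time of 4 days (on this read-out lower numbers stand for higher toxicity in this test and higher numbers for lower toxicity in this test), compound 1 gives 2890 nM, compound 2 gives 4170 nM and compound 3 gives 4120 nM. The three steps, a 1.4-fold higher number from compound 1 to compound 2 (0.16 log units; within the scatter), a 1.4-fold higher number from compound 1 to compound 3 (0.15 log units; within the scatter) and a 1.0-fold lower number from compound 2 to compound 3 (0.01 log units; within the scatter), all stay inside the scatter, so the three numbers cannot be ranked against one another. On the numbers shown, compound 3 stands second highest of three; its nearest neighbour is compound 2 and its furthest is compound 1, both within the scatter.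

Compound 4 `Cc1ccccc1-c1cc(C)c(Nc2ccnc(Nc3ccc(C#N)cc3)n2)c(C)c1` takes the change (2-methylphenyl in place of 3-fluorophenyl on an aromatic carbon). Going by the values given here, two measured steps bear on this: the aryl swap a 1.4-fold higher number from compound 1 to compound 3 (0.15 log units; within the scatter) and the fluoro-for-hydrogen change a 1.0-fold lower number from compound 2 to compound 3 (0.01 log units; within the scatter), and both are within the scatter. Among the compounds with values here, no measured step in this set on this assay exceeds the scatter, so a further change of the aryl group is expected to move the number by no more than the scatter, in either direction. The estimated step of a 1.0-fold lower number from compound 3 to compound 4 (0.01 log units; within the scatter) is expected to stay small. Compound 4 is therefore estimated at 4000 nM in this assay, with a range from 2000 nM to 8000 nM.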

Compound 4, half-maximal cytotoxic concentration: 3820 nM
Compound 4: the middle estimate sits 1.0-fold (0.02 log units) above what was measured; the measured number falls inside the stated range.
By their numbers in this assay, from the lowest: compounds 1, 4, 3 and 2 (each within the scatter of the next).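

At this aromatic carbon, meta to two methyl groups and para to a large group, the 2-methylphenyl group joins the three aryl groups already read in this assay, and none of its steps leaves the scatter: against 3-fluorophenyl (a 1.1-fold lower number from compound 3 to compound 4 (0.03 log units; within the scatter)), against the unsubstituted phenyl (a 1.1-fold lower number from compound 2 to compound 4 (0.04 log units; within the scatter)) and against 4-methoxyphenyl (a 1.3-fold higher number from compound 1 to compound 4 (0.12 log units; within the scatter)). The methyl-for-hydrogen step extends the earlier picture, which held only fluoro and methoxy on the aryl group, to a carbon-only substituent at a further place on that ring, so the four compounds now form one group that cannot be ranked on this read-out. Nothing shown accounts for this lack of separation.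

Going by these compounds, whether the number stays within the scatter when the aryl group carries a carboxylic acid or a primary amine remains open. Going by these compounds alone, also open is whether a saturated chain such as hexyl on this carbon, in place of the aryl group, would give the first step beyond the scatter at this position.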